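This account rests on a few compounds, and the source may have more. Where it says the series, first, only, none or still open, it means among the compounds named here.

Of the compounds shown here, three have been tested in a functional assay on S1B1-20 cells (Homo sapiens); a lower number here means a stronger inhibitor, a higher number a weaker inhibitor. Compound 1 `COc1cc2c(cc1OC)CN(CCCCCCC(Sc1ccccc1)c1ccccc1)CC2` gives 3820 nM, compound 2 `COc1ccc(C(CCCCCCN2CCc3cc(OC)c(OC)c(OC)c3C2)Sc2ccc(C)cc2)cc1OC` gives 700 nM, and compound 3 `COc1ccc(C(CCCCCN2CCc3cc(OC)c(OC)cc3C2)SC2CCCCC2)cc1OC` gives 730 nM. Compound 3 therefore stands second highest of the three numbers, although its value and that of compound 2 lie within the usual scatter of each other, while compound 1 sits clearly higher, beyond the scatter. Compound 4 `CCCCCSC(CCCCCN1CCc2cc(OC)c(OC)cc2C1)c1ccc(OC)c(OC)c1` differs from compound 3 in a single place: pentyl in place of cyclohexyl on a sulfur. Within the data shown here, no measured pair shows this exchange, so its effect is unknown; the expectation is a small step in this assay, most likely none beyond the scatter, in either direction. For compound 4 the estimated value is 900 nM, with a range from 300 nM to 2700 nM, which means an expected step of a 1.2-fold higher number from compound 3 to compound 4 (0.09 log units; within the scatter).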

Compound 4, half-maximal inhibitory concentration: 500 nM
The estimate for compound 4 lay 1.8-fold (0.26 log units) above the measured number; measured number inside the range.
By their numbers in this assay, from the lowest: compounds 4, 2 and 3 (each within the scatter of the next); then compound 1.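

Putting pentyl in place of cyclohexyl on the sulfur gives a 1.5-fold lower number from compound 3 to compound 4 (0.16 log units; within the scatter) in this assay. The two compounds therefore cannot be told apart in this read-out, so on this sulfur an open carbon chain serves as well as a six-membered carbon ring. Nothing available explains this result. Still open, going by these compounds, is whether a much shorter group such as methyl would move the number beyond the scatter. So is whether a chain ending in an amine or a carboxylic acid would do so.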